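Replacing an Amino Group on a Fused Core

The compounds below may be only part of what the source reports. "The series", "measured", "known", "first", "only" and "open" are said of these compounds alone.

Measured compounds:
compound 1, `Cc1ccc(C(=O)Nc2ccc(Cl)cc2C(N)=O)cc1`, gives 5.39 ug/mL in a functional assay on MCF7 cells (Homo sapiens) for antiproliferative activity, read by MTT assay, with a stated time of 48 h; a higher number here means a weaker inhibitor, a lower number a stronger inhibitor
compound 2, `Cc1ccc(-c2nc(N)c3cc(Cl)ccc3n2)cc1`, gives 3.76 ug/mL
compound 3, `Cc1ccc(C(=O)Nc2ccc(Cl)cc2C(=S)NN)cc1`, gives 3.35 ug/mL

Compound 2 holds the second highest of the three numbers, and its gaps to compound 3 and to compound 1 both lie within the scatter, so the three compounds stand together. Compound 4, `Cc1ccc(-c2nc(SCC#N)c3cc(Cl)ccc3n2)cc1`, differs from compound 2 in one place: (cyanomethyl)sulfanyl in place of amino on an aromatic carbon. Going by the values given here, the only measured step, a 1.6-fold lower number from compound 1 to compound 3 (0.21 log units; within the scatter), concerns a different group on the core of compound 1 and stayed within the scatter; no measured step swaps an amino group for a sulfur-linked chain. Compound 4 is therefore expected to stay close to compound 2. The expected step is a 1.1-fold lower number from compound 2 to compound 4 (0.03 log units; within the scatter). In this assay compound 4 is estimated at 3.5 ug/mL, with a range from 1.5 ug/mL to 9 ug/mL.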

Compound 4, half-maximal inhibitory concentration: 3.35 ug/mL
Compound 4: the middle estimate sits 1.0-fold (0.02 log units) above what was measured; the measured number falls inside the stated range.
By their numbers in this assay, from the lowest: compounds 3, 4, 2 and 1 (each within the scatter of the next).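

In this assay, going by these compounds alone, the step (a 1.1-fold lower number from compound 2 to compound 4 (0.05 log units; within the scatter)) is the first measured change at this position, on the ring with two nitrogens in the shared core, and it stays within the scatter. The amino group carries a hydrogen-bond donor and the larger (cyanomethyl)sulfanyl carries none, yet the two numbers stand together. No evidence here explains this closeness. Going by these compounds, it remains open whether a longer sulfur-linked chain, a carboxylic acid or a dimethylamino group at this position would move the number beyond the scatter.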